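The compounds below may be only part of what the source reports. "The series", "measured", "known", "first", "only" and "open" are said of these compounds alone.

Within the data shown here, compound 2, `O=C(O)CN(C/C=C/c1cccc(Oc2ccccc2)c1)C/C=C/c1cccc(Oc2ccccc2)c1`, is the weaker of the two compounds measured so far in an assay on isolated protein for binding affinity to erythropoietin receptor (Homo sapiens); on this read-out higher numbers stand for weaker inhibition and lower numbers for stronger inhibition: compound 2 gives 85000 nM. Compound 1, `COC(=O)[C@H](CCCCNC(N)=O)N(C/C=C/c1cccc(Oc2ccccc2)c1)C/C=C/c1cccc(Oc2ccccc2)c1`, carries a longer substituted chain with a methyl ester on the carbon that bears the amine, and in this assay compound 1 gives 35000 nM, a number that is lower than that of compound 2 by more than the usual scatter. The two compounds differ in more than one place, so the two values are simply what they are, with no single change to tie them to.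

Compound 3, `O=C(O)CC[C@@H](C(=O)O)N(C/C=C/c1cccc(Oc2ccccc2)c1)C/C=C/c1cccc(Oc2ccccc2)c1`, is built from compound 2 by one change: 2-carboxyethyl in place of hydrogen on a saturated chain carbon bound to an amine nitrogen and a carbonyl carbon. The carbon that sits between the amine nitrogen and the carbonyl thereby gains a second acid group on a short chain, and the compound has not yet been measured in this assay.

Among the measured compounds shown here, because compound 1 gives 35000 nM as the only other compound with a substituent at that carbon, a modest move toward a lower number is expected for the step from compound 2 to compound 3, about a 2.1-fold lower number from compound 2 to compound 3 (0.33 log units; beyond the scatter). For compound 3 the estimated value is 40000 nM, within a range from 15000 nM to 120000 nM.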

Compound 3, half-maximal inhibitory concentration: 42000 nM
Estimate against measurement, compound 3: 1.1-fold (0.02 log units) below; the measured number falls inside the stated range.
By their numbers in this assay, from the lowest: compounds 1 and 3 (each within the scatter of the next); then compound 2.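

In this assay, the change from hydrogen to 2-carboxyethyl on this saturated chain carbon gives a 2.0-fold lower number from compound 2 to compound 3 (0.31 log units; beyond the scatter), the first effect in this set that can be tied to a single change. This shows that the position can carry a substituent of 5 heavy atoms without the number rising; the step runs modestly toward stronger inhibition, and compound 3 still gives 42000 nM, so the added chain refines a weak binder and does not turn it into a strong one. The compounds shown offer no independent measurement that could explain the step, so it stands as an observed outcome only.

From the compounds shown here alone, one step at one position cannot separate the contribution of the chain itself from that of the carboxylic acid at its end, so it remains open whether a plain ethyl chain, or a chain of the same length ending in an amine, would move the number in the same way. Also open, going by these compounds, is how a longer chain ending in a carboxylic acid would behave, and whether the opposite spatial arrangement at this carbon would give the same value.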